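The source may report more compounds than this note shows. Statements on the series, on what has been measured and on what is new or still open speak of the compounds shown alone.

Compound 1 `O=C(Nc1cccc(-c2ccco2)c1)C1CCCN(C(=O)c2cc(C(F)(F)F)cc(C(F)(F)F)c2)C1` is one of three compounds tested in an ADME assay on PC-3 cells (Homo sapiens) for cytotoxicity, read by WST assay, tested at 100 uM (on this read-out higher numbers stand for more inhibition at the one concentration tested (going by the name of the read-out) and lower numbers for less inhibition), where compound 1 gives 0%. Compound 2 `O=C(Nc1cccc(Oc2ccccc2)c1)C1CCCN(C(=O)c2cccc(-c3ccco3)c2)C1` gives 0% and compound 3 `O=C(Nc1cccc(Cc2ccccc2)c1)C1CCCN(C(=O)c2cccc(-c3ccco3)c2)C1` gives 0%, so compound 1 stands level with both of them at the digits shown. Among the compounds with values here, the only measured step, no change at the digits printed from compound 2 to compound 3 (within the scatter), comes from putting benzyl in place of phenoxy on an aromatic carbon.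

Compound 4 `O=C(Nc1cccc(Cc2ccccc2)c1)C1CCCN(C(=O)c2cc(C(F)(F)F)cc(C(F)(F)F)c2)C1` differs from compound 1 by benzyl in place of furan-2-yl on an aromatic carbon. Within the data shown here, no measured step swaps furan-2-yl for benzyl, but benzyl entering elsewhere left no change at the digits printed from compound 2 to compound 3 (within the scatter), and all three measured values sit at the same level. The expected step in this assay is therefore no change at the digits printed from compound 1 to compound 4 (within the scatter), with no change beyond the scatter. Compound 4 is expected to give 0%, in a range from -5% to 12%.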

Compound 4, a percentage reported as inhibition, at one concentration (the size of the read-out at that concentration, not a potency): 0%
For compound 4 middle estimate and measured number coincide at the digits printed; the measured number falls inside the stated range.
By their numbers in this assay, from the lowest: compounds 1, 2, 3 and 4 (each within the scatter of the next).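

Putting benzyl in place of furan-2-yl on this aromatic carbon, meta to a large group, gives no change at the digits printed from compound 1 to compound 4 (within the scatter) in this assay. This position therefore accepts a swap from a five-membered aromatic ring with one hetero atom to a six-membered carbon ring without any shift in the read-out, here with both trifluoromethyl groups kept in place. Nothing available explains this flat result.

On these data alone, whether an amine or a carboxylic acid at this position would move the read-out remains open. With all four values level, these compounds do not show which parts of the structure, if any, can affect it.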